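Oxime variants on a shared core: toward compound 4

This account rests on a few compounds, and the source may have more. Where it says the series, first, only, none or still open, it means among the compounds named here.

Measured so far in a functional assay (blood) for inhibition, with Homo sapiens as the target; on this read-out higher numbers stand for weaker inhibition and lower numbers for stronger inhibition:
compound 1 `CCOC(=O)/C(=N\O)c1ccc(Sc2cc(F)cc(C3CCOCC3)c2)cc1`, 170 nM
compound 2 `CC(=O)O/N=C(\C)c1ccc(Sc2cc(F)cc(C3CCOCC3)c2)cc1`, 50 nM
compound 3 `CCOC(=O)CO/N=C(\C)c1ccc(Sc2cc(F)cc(C3CCOCC3)c2)cc1`, 610 nM

Compound 3 carries the highest number of the three; the step of a 3.6-fold higher number from compound 1 to compound 3 (0.55 log units; beyond the scatter) separates it from compound 1, and the step of a 12-fold higher number from compound 2 to compound 3 (1.09 log units; beyond the scatter) from compound 2. Compound 4 `O/N=C/c1ccc(Sc2cc(F)cc(C3CCOCC3)c2)cc1` differs from compound 3 in one place: a group of 3 heavy atoms (1 carbon, 1 nitrogen, 1 oxygen; no ring) in place of a group of 10 heavy atoms (6 carbon, 1 nitrogen, 3 oxygen; no ring), on an aromatic carbon.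

Among the measured compounds shown here, two measured steps bear on this change. The step of a 12-fold higher number from compound 2 to compound 3 (1.09 log units; beyond the scatter) shows that altering the part beyond the oxime oxygen moves this assay by a large amount, and the step of a 3.6-fold higher number from compound 1 to compound 3 (0.55 log units; beyond the scatter) shows a modest move between the two larger groups. Compound 1, whose group carries one hydrogen-bond donor as compound 4 does, sits well below compound 3, so a modest step downward is expected, a 4.1-fold lower number from compound 3 to compound 4 (0.61 log units; beyond the scatter). Compound 4 is estimated at 150 nM, within 40 nM to 600 nM.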

Compound 4, half-maximal inhibitory concentration: 120 nM
For compound 4 the middle estimate is 1.3-fold (0.10 log units) above the measured one; low and high end bracket the measured number.
By their numbers in this assay, from the lowest: compound 2; then compounds 4 and 1 (each within the scatter of the next); then compound 3.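

On this aromatic carbon, in this assay, the smaller group with 1 hydrogen-bond donor gives a 5.1-fold lower number from compound 3 to compound 4 (0.71 log units; beyond the scatter), so the larger substituted oxime of compound 3 is not needed for the lower number. Size alone does not order the series: a 2.4-fold higher number from compound 2 to compound 4 (0.38 log units; beyond the scatter), leaving the acetyl-bearing group of compound 2 ahead, while a 1.4-fold lower number from compound 1 to compound 4 (0.15 log units; within the scatter) does not separate those two groups. Nothing here gives a reason for these steps.

Still open, going by these compounds, is how a carboxylic acid or an amine at this carbon would read in this assay. Also open, on these data alone, is whether a longer acyl chain on the oxime oxygen would keep the number of compound 2, 50 nM.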